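The source may hold more compounds than are shown below. What is called first, only, known or untested is meant among the compounds shown, and "the series" means these compounds.

Measured compounds:

compound 1, `Cc1cc(C)c(-c2c(C)nn(C)c2C)cc1NC(=O)c1ccc(OCc2ccccn2)cc1`
compound 2, `Cc1cc(C)c(-c2ccccn2)cc1NC(=O)c1ccc(OCc2ccccn2)cc1`
compound 3, `Cc1cc(C)c(-c2ccc(N)cn2)cc1NC(=O)c1ccc(OCc2ccccn2)cc1`

In a physicochemical assay for lipophilicity (a higher number here means a more lipophilic compound, a lower number a more polar compound), compound 1 gives > 3, which is a limit of the assay rather than a number. Compound 2 likewise gives > 3, also a limit. Among the measured compounds shown here, compound 3 gives 3.2 and is the only compound of the three with a number; the other two values sit at the limit of > 3 in this assay, at which 2 of the 3 values shown sit. The steps from compound 1 to compound 3 and from compound 2 to compound 3 are therefore not readable in size: a step that the limit leaves unreadable from compound 1 to compound 3, a step that the limit leaves unreadable from compound 2 to compound 3. The step from compound 1 to compound 2 is unreadable as well, a step that the two limits leave unreadable from compound 1 to compound 2.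

The next compound, compound 4, is `Cc1cc(C)c(-c2cccc(N)n2)cc1NC(=O)c1ccc(OCc2ccccn2)cc1`. It differs from compound 3 by 6-aminopyridin-2-yl in place of 5-aminopyridin-2-yl on an aromatic carbon. For the measured compounds named here, the two share the same atoms, joined differently, so no measured step speaks to this change, and the unreadable steps give no direction either. The expected step from compound 3 to compound 4 in this assay is accordingly none beyond the scatter, no change at the digits printed from compound 3 to compound 4 (within the scatter). Compound 4 is estimated at 3.2, with a range from 2.8 to 3.6, and a fair chance that this assay again reports only a limit.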

Compound 4, distribution coefficient: > 3
Compound 4 ended at the assay's limit (the forecaster's own chance of this, stated with the estimate: 35%); the middle value lies beyond the limit too.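

In this assay compound 4 gives > 3, which is a limit of the assay and not a number, so the steps linking compound 4 with compound 1, compound 2 and compound 3 cannot be read in size. The compounds shown leave open whether 6-aminopyridin-2-yl in place of 5-aminopyridin-2-yl shifts the read-out at all, and in which direction.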